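Fluoro on the phenyl of compound 1: expected effect

The source may report more compounds than this note shows. Statements on the series, on what has been measured and on what is new or still open speak of the compounds shown alone.

Compound 1 `Cc1ncc([N+](=O)[O-])n1CCSc1nnc(-c2ccccc2)o1` is one of two members of this series tested in a functional assay on SGC-7901 cells (Homo sapiens) for cytotoxicity, read by MTT assay, with a stated time of 48 h; on this read-out lower numbers stand for stronger inhibition and higher numbers for weaker inhibition; compound 1 gives 30100 nM, a number that sits within the scatter of its only companion. That companion, compound 2 `Cc1ccccc1-c1nnc(SCCn2c([N+](=O)[O-])cnc2C)o1`, carries a methyl on an aromatic carbon of the phenyl, and in this assay compound 2 gives 32300 nM. Among the compounds with values here, the only measured step, a 1.1-fold higher number from compound 1 to compound 2 (0.03 log units; within the scatter), shows the read-out unchanged beyond the scatter by that substitution.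

Compound 3 `Cc1ncc([N+](=O)[O-])n1CCSc1nnc(-c2ccccc2F)o1` differs from compound 1 by fluoro in place of hydrogen on an aromatic carbon. Within the data shown here, the single step that bears on this change, a 1.1-fold higher number from compound 1 to compound 2 (0.03 log units; within the scatter), lay within the scatter. A fluoro on the same phenyl is therefore expected to give a step of a 1.0-fold lower number from compound 1 to compound 3 (0.00 log units; within the scatter) that stays within the scatter as well. In this assay, compound 3 is expected to give 30000 nM, with a range from 12000 nM to 75000 nM.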

Compound 3, half-maximal inhibitory concentration: 33700 nM
Compound 3: the middle estimate sits 1.1-fold (0.05 log units) below what was measured; the range from low to high includes it.
By their numbers in this assay, from the lowest: compounds 1, 2 and 3 (each within the scatter of the next).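

In this assay, the step for fluoro in place of hydrogen ortho to a large group, a 1.1-fold higher number from compound 1 to compound 3 (0.05 log units; within the scatter), adds a second substituent at this place that leaves the read-out within the scatter. The exchange of one substituent for the other, a 1.0-fold higher number from compound 2 to compound 3 (0.02 log units; within the scatter), also stays within the scatter, so hydrogen, methyl and fluoro at this place cannot be told apart on this read-out. Nothing available accounts for this insensitivity.

As far as these compounds go, whether any group at this place can move the number beyond the scatter remains open, for instance an amine, a carboxylic acid or a longer chain. The compounds shown also leave open whether fluoro on another carbon of the same ring would behave as it does here.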